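Shedding a Hydroxyl from the Shared Core

A few compounds are considered here, and "the series" means these few. Any claim that something is new, unique, unknown or untested is made for them only; others in the source may bear on it.

Compound 1 `Oc1ccc(C2=NN(c3ccc(Cl)cc3)C(c3ccc(Cl)cc3)C2)c(O)c1` was tested in an assay on HEK293 cells for inhibition of protein kinase C zeta type (Homo sapiens), read by 33P incorporation, with a stated time of 40 min, in the presence of a further agent that is not named here (a higher number here means a weaker inhibitor, a lower number a stronger inhibitor), where compound 1 gives 4300 nM. For the measured compounds named here, that is the only outright number here. Compound 2 `Oc1ccc(C2=NN(c3cccc(Cl)c3)C(c3ccc(Cl)cc3)C2)cc1` stops at a limit of the assay, as compound 2 gives < 100 nM. The same point is noted in the limit of < 100 nM in this assay, at which 1 of the 2 values shown sits. Compound 3 `Oc1cccc(C2=NN(c3ccc(Cl)cc3)C(c3ccc(Cl)cc3)C2)c1` differs from compound 1 by 3-hydroxyphenyl in place of 2,4-dihydroxyphenyl on a carbon with a double bond to nitrogen. Going by the values given here, no measured pair mirrors this change, so the step is expected to be a modest gain, a 4.8-fold lower number from compound 1 to compound 3 (0.68 log units; beyond the scatter). Compound 3 is estimated at 900 nM in this assay, between 150 nM and 5000 nM.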

Compound 3, half-maximal inhibitory concentration: 6500 nM
Beside the measured number, compound 3's estimate is 7.2-fold (0.86 log units) below it; the measured number lies above the stated range.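

Putting 3-hydroxyphenyl in place of 2,4-dihydroxyphenyl on the carbon with a double bond to nitrogen gives a 1.5-fold higher number from compound 1 to compound 3 (0.18 log units; within the scatter) in this assay and so leaves compound 1 and compound 3 indistinguishable. At this position, then, this pair tolerates the swap without a readable change in inhibition. Nothing shown here explains why this swap leaves the reading unchanged.

The swap alters both the number and the placing of the hydroxyl groups, so the two effects cannot be separated. On these data alone, how an amine or a carboxylic acid on this ring would behave remains open.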